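Replacing a Side Chain with (Piperidin-1-yl)carbonyl

A few compounds are considered here, and "the series" means these few. Any claim that something is new, unique, unknown or untested is made for them only; others in the source may bear on it.

In a functional assay (aorta) with Rattus norvegicus as the target (a higher number here means that more compound is needed for the effect, a lower number that less compound is needed), compound 1 (`C/N=C(/NC)Nc1nc(-c2ccc(OC)cc2)c(-c2ccc(OC)cc2)s1`) gives 2.4 uM, compound 2 (`COc1ccc(-c2nc(CNC(=O)c3cccnc3)sc2-c2ccc(OC)cc2)cc1`) gives 8.2 uM and compound 3 (`COc1ccc(-c2nc(CNC(=O)CSC)sc2-c2ccc(OC)cc2)cc1`) gives 6 uM. Compound 3 therefore sits in the upper part of this small range: a 1.4-fold lower number from compound 2 to compound 3 (0.14 log units; within the scatter), and a 2.5-fold higher number from compound 1 to compound 3 (0.40 log units; beyond the scatter). Compound 4 (`COc1ccc(-c2nc(C(=O)N3CCCCC3)sc2-c2ccc(OC)cc2)cc1`) carries (piperidin-1-yl)carbonyl in place of ((((methylsulfanyl)methyl)carbonyl)amino)methyl on an aromatic carbon. Among the measured compounds shown here, no measured step makes this exact change. The closest guides are the side-chain changes above and a 3.4-fold higher number from compound 1 to compound 2 (0.53 log units; beyond the scatter), and all three are small or modest. In this assay, no step beyond the scatter is therefore expected, in either direction: the expected step is no change at the digits printed from compound 3 to compound 4 (within the scatter). For compound 4 the estimated value is 6 uM, within a range of 2 uM to 18 uM.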

Compound 4, concentration for half-maximal effect: 11 uM
The estimate for compound 4 lay 1.8-fold (0.26 log units) below the measured number; the measured number falls inside the stated range.
By their numbers in this assay, from the lowest: compound 1; then compounds 3, 2 and 4 (each within the scatter of the next).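

Swapping the open-chain ((((methylsulfanyl)methyl)carbonyl)amino)methyl, which has a hydrogen-bond donor, for the ring-bearing (piperidin-1-yl)carbonyl, which has none, stays within the scatter in this assay: a 1.8-fold higher number from compound 3 to compound 4 (0.26 log units; within the scatter), and likewise a 1.3-fold higher number from compound 2 to compound 4 (0.13 log units; within the scatter). A side chain without a hydrogen-bond donor is thus accepted on this aromatic carbon about as well as the two amide chains, while the gap to the first compound remains: a 4.6-fold higher number from compound 1 to compound 4 (0.66 log units; beyond the scatter). Nothing measured here explains these numbers. As far as these compounds go, whether a simple amine or a carboxylic acid on this carbon would come closer to compound 1 remains open.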